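A few compounds are considered here, and "the series" means these few. Any claim that something is new, unique, unknown or untested is made for them only; others in the source may bear on it.

Working notes on the series. Within the data shown here, in a functional assay on DU-145 cells (Homo sapiens) for cytotoxicity, read by trypan blue exclusion, with a stated time of 96 h (on this read-out higher numbers stand for weaker inhibition and lower numbers for stronger inhibition), compound 1 (`COc1cc(OC)c(/C=C/S(=O)(=O)Cc2ccc(F)c(N)c2)c(OC)c1`) gives 2500 nM as the lowest of the three numbers measured so far. Compound 3 (`COc1cc(OC)c(/C=C/S(=O)(=O)Cc2ccc(Br)c([N+](=O)[O-])c2)c(OC)c1`) gives 25000 nM and compound 2 (`COc1ccc(CS(=O)(=O)/C=C/c2c(OC)cccc2OC)c([N+](=O)[O-])c1`) gives 50000 nM in the same read-out, and both numbers lie beyond the scatter from that of compound 1.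

Among the measured compounds shown here, compound 4 (`COc1cc(OC)c(/C=C/S(=O)(=O)Cc2ccc(Cl)c(N)c2)c(OC)c1`) has no measurement yet. Against compound 1 its structure changes by chloro in place of fluoro on an aromatic carbon and nothing else: chloro in place of fluoro on an aromatic carbon, ortho to an amino group and para to a large group. The same difference reads 3-amino-4-fluorophenyl to 3-amino-4-chlorophenyl.

For the measured compounds named here, no two measured compounds differ in one place, so the series offers no measured step for this exchange, and its size has to be judged from the closest neighbour alone. The step of no change at the digits printed from compound 1 to compound 4 (within the scatter) is expected to stay within the scatter in this assay with neither direction favoured by the data. Going by the values given here, this expectation rests on compound 1 at 2500 nM as the only measured compound that differs from compound 4 in a single place. Compound 4 is estimated at 2500 nM with an expected range from 800 nM to 8000 nM in this assay pending measurement.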

Compound 4, half-maximal inhibitory concentration: 10 nM
For compound 4 the middle estimate is 250-fold (2.40 log units) above the measured one; measured number outside the range, below it.
By their numbers in this assay, from the lowest: compound 4; then compound 1; then compounds 3 and 2 (each within the scatter of the next).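

In this assay, the aromatic carbon ortho to an amino group and para to a large group proves highly sensitive: chloro in place of fluoro gives a 250-fold lower number from compound 1 to compound 4 (2.40 log units; beyond the scatter). The earlier compounds shown here could not show this, as none of them formed a one-place pair, whereas here 1 heavy atom leaves and 1 heavy atom enters, with no ring, hydrogen-bond donor, hydrogen-bond acceptor or net charge on either side of the exchange, and the read-out still moves by a large step beyond the scatter. Nothing available accounts for the size of this step, so it stands as an observation without an explanation.

The compounds shown leave open whether the step is particular to chloro or whether a methyl or trifluoromethyl group on the same aromatic carbon would also give a low number in this read-out. They also leave open whether the step depends on the neighbouring amino group, a question that a hydroxyl or acetamide group in its place, with chloro kept, would address.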